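The compounds below may be only part of what the source reports. "The series", "measured", "known", "first", "only" and "open" are said of these compounds alone.

Measured so far in a functional assay on SF-539 cells (Homo sapiens) for inhibition, read by sulforhodamine B assay, with a stated time of 48 h; on this read-out lower numbers stand for stronger inhibition of growth and higher numbers for weaker inhibition of growth:
- compound 1 `COc1cc(-c2nn(-c3cccc(NC(=O)Nc4cc(C(F)(F)F)cc(C(F)(F)F)c4)c3)cc2-c2ccncc2)ccc1Cl`: 1710 nM
- compound 2 `COc1cc(-c2nn(-c3cccc(NC(=O)c4cccc(C(F)(F)F)c4)c3)cc2-c2ccncc2)ccc1Cl`: 2300 nM

Compound 2 carries the larger of the two numbers in this assay, but compound 1 lies within the usual scatter of it, so no ordering between the two is claimed; both sit in the same band of total growth inhibition. Compound 1 is a urea bearing two trifluoromethyl groups, compound 2 an amide bearing one; the two values show that this combined change leaves the read-out essentially unmoved.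

Compound 3 `COc1cc(-c2nn(-c3cccc(NC(=O)Nc4cccc(C(F)(F)F)c4)c3)cc2-c2ccncc2)ccc1Cl` is not yet measured in this assay. Relative to compound 2 it differs in one place: (3-(trifluoromethyl)phenyl)amino in place of 3-(trifluoromethyl)phenyl on a carbonyl carbon. It is therefore the urea counterpart of compound 2 and, at the same time, compound 1 stripped of one trifluoromethyl group.

Among the compounds with values here, no single-change step between measured compounds is available, so the size of the move cannot be read off directly. Given that compound 1 at 1710 nM and compound 2 at 2300 nM lie within the scatter of each other, the step of a 1.2-fold lower number from compound 2 to compound 3 (0.08 log units; within the scatter) is expected to be small, with no direction claimed beyond the scatter. Compound 3 is estimated at 1900 nM in this assay, within 700 nM to 5000 nM.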

Compound 3, concentration for total growth inhibition: 2420 nM
The estimate for compound 3 lay 1.3-fold (0.11 log units) below the measured number, and the stated range covers the measured number.
By their numbers in this assay, from the lowest: compounds 1, 2 and 3 (each within the scatter of the next).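

In this assay, (3-(trifluoromethyl)phenyl)amino in place of 3-(trifluoromethyl)phenyl on a carbonyl carbon gives a 1.1-fold higher number from compound 2 to compound 3 (0.02 log units; within the scatter) and so shows that, with a single trifluoromethyl group held constant, the read-out does not separate the urea from the amide. Hydrogen in place of trifluoromethyl on an aromatic carbon gives a 1.4-fold higher number from compound 1 to compound 3 (0.15 log units; within the scatter) and so isolates the second trifluoromethyl group, which also leaves the read-out unresolved; the combined difference between compound 1 and compound 2 now splits into two single changes, each within the scatter. Nothing on hand offers an explanation for this flat response.

The compounds shown leave open whether this end of the series responds to any change at all, since all three keep an aromatic ring bearing trifluoromethyl on the linker. Chlorine or methoxy in place of trifluoromethyl, a saturated amine such as piperidine in place of the aromatic ring, or a carboxylic acid on that ring would test whether the band of total growth inhibition can move from this position.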